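Series notes: methyl on the benzyl ring of compound 3

The source may hold more compounds than are shown below. What is called first, only, known or untested is meant among the compounds shown, and "the series" means these compounds.

Compound 3 `Cn1c(-c2ccc(NC(=O)CN3CCN(Cc4ccccc4)CC3)cc2)nc(-c2ccccc2)c1-c1ccccc1` in a functional assay on MCF7 cells (Homo sapiens) for cytotoxicity, read by MTT assay, with a stated time of 24 h (on this read-out lower numbers stand for stronger inhibition and higher numbers for weaker inhibition), gives 80 ug/mL. Compound 2 `CCN1CCN(CC(=O)Nc2ccc(-c3nc(-c4ccccc4)c(-c4ccccc4)n3C)cc2)CC1` in this assay gives 80 ug/mL, and compound 1 `CN1CCN(CC(=O)Nc2ccc(-c3nc(-c4ccccc4)c(-c4ccccc4)n3C)cc2)CC1` in this assay gives 76.5 ug/mL. Compound 3 stands level with compound 2 at the digits shown, and compound 1 lies within the scatter of both: a 1.0-fold higher number from compound 1 to compound 2 (0.02 log units; within the scatter), a 1.0-fold higher number from compound 1 to compound 3 (0.02 log units; within the scatter) and no change at the digits printed from compound 2 to compound 3 (within the scatter). The three groups tried on the saturated chain carbon bound to the amine nitrogen in the ring thus leave the read-out unmoved.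

Compound 4 `Cc1ccc(CN2CCN(CC(=O)Nc3ccc(-c4nc(-c5ccccc5)c(-c5ccccc5)n4C)cc3)CC2)cc1` differs from compound 3 by methyl in place of hydrogen on an aromatic carbon. Within the data shown here, no measured step touches this aromatic carbon; the measured steps, all within the scatter, concern only the saturated chain carbon, and the nearest of them in kind is no change at the digits printed from compound 2 to compound 3 (within the scatter). No step beyond the scatter is therefore expected for no change at the digits printed from compound 3 to compound 4 (within the scatter). Compound 4 is expected to give 80 ug/mL in this assay, with a range of 40 ug/mL to 160 ug/mL.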

Compound 4, half-maximal inhibitory concentration: 80 ug/mL
For compound 4 middle estimate and measured number coincide at the digits printed, and the stated range covers the measured number.
By their numbers in this assay, from the lowest: compounds 1, 2, 3 and 4 (each within the scatter of the next).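

On the aromatic carbon para to a large group, methyl in place of hydrogen gives no change at the digits printed from compound 3 to compound 4 (within the scatter) in this assay, so this first look at the benzyl ring shows no measurable response to the added methyl. Measured against the smaller groups on the saturated chain carbon, 4-methylphenyl gives no change at the digits printed from compound 2 to compound 4 (within the scatter) and a 1.0-fold higher number from compound 1 to compound 4 (0.02 log units; within the scatter), which extends the flat read-out at that carbon to a fourth group. No available evidence bears on this flat read-out.

On these data alone, whether a chlorine, a methoxy, an amine or a carboxylic acid on this aromatic carbon would give a step beyond the scatter remains open. Also open, as far as these compounds go, is whether a methyl on another carbon of the ring, or a change in the shared core or the amide, would move the number.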